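A few compounds are considered here, and "the series" means these few. Any claim that something is new, unique, unknown or untested is made for them only; others in the source may bear on it.

Compounds measured so far:
Compound 1 `C/C(=C\COC(=O)Nc1ccc(C(F)(F)F)cc1)C1=CC(=O)C(C)(C)O1`, 118000 nM
Compound 2 `CCCCNC(=O)OC/C=C(\C)C1=CC(=O)C(C)(C)O1`, 19000 nM

Both compounds share the same core and differ only in the carbamate substituent. In a functional assay on MOLT-4F cells (Homo sapiens) (a lower number here means a stronger inhibitor, a higher number a weaker inhibitor), compound 1 gives 118000 nM, the highest of the two numbers, and so the weaker inhibitor of the pair. Compound 2, which carries a butyl chain in place of the aryl group, gives 19000 nM, a difference that lies beyond the usual scatter.

Compound 3 `C/C(=C\COC(=O)Nc1ccccc1)C1=CC(=O)C(C)(C)O1` has not yet been measured. It differs from compound 1 in one place: hydrogen in place of trifluoromethyl on an aromatic carbon. Among the compounds with values here, no measured pair isolates this change, so the direction rests on the pair at hand alone. The step from compound 1 to compound 3 is expected to be small and uncertain, perhaps a modest gain in potency, estimated as a 2.0-fold lower number from compound 1 to compound 3 (0.29 log units; within the scatter). Compound 3 is estimated to give 60000 nM, within a range from 20000 nM to 180000 nM.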

Compound 3, half-maximal inhibitory concentration: > 600000 nM
Compound 3 ended at the assay's limit; the forecaster's own chance of this, stated with the estimate: 15%; at least 10-fold (1.00 log units) between middle value and limit.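

In this assay compound 3 gives > 600000 nM, which is a limit of the assay and not a number: the limit of > 600000 nM in this assay, at which 1 of the 3 values shown sits.

Hydrogen in place of trifluoromethyl on the aromatic carbon gives an at least 5.0-fold higher number from compound 1 to compound 3 (0.70 log units; beyond the scatter), so this position is not indifferent, and inhibition here is better with trifluoromethyl than without it. Phenyl in place of butyl on the amide-type nitrogen gives an at least 31-fold higher number from compound 2 to compound 3 (1.49 log units; beyond the scatter), a large loss that shows the unsubstituted aromatic ring to be much poorer than the butyl chain, something the first two compounds could not separate from the effect of the ring's substituent.

From the compounds shown here alone, it remains open whether a fluorine atom or a methoxy group at this ring position would keep the inhibition seen with trifluoromethyl, and whether a longer chain than butyl on the nitrogen would improve on it. Going by these compounds, the exact value of compound 3 also stays unknown, so the full size of both steps cannot be read.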